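The source may report more compounds than this note shows. Statements on the series, on what has been measured and on what is new or still open speak of the compounds shown alone.

Working notes on the series. Within the data shown here, in a functional assay on CCRF-CEM cells (Homo sapiens) (on this read-out lower numbers stand for stronger inhibition and higher numbers for weaker inhibition), compound 1 `Cc1ccc(-c2ncnc3c2ncn3C[C@@H]2C[C@H](CO)c3ccccc32)cc1` gives 1.4 ug/mL, the lower of the two numbers so far. Compound 2 `Cn1ncc2c1[C@@H](CO[Si](c1ccccc1)(c1ccccc1)C(C)(C)C)C[C@H]2Cn1cnc2c(O)ncnc21` gives 3.2 ug/mL, and the gap between the two lies beyond the usual scatter, with compound 1 the stronger inhibitor.

Compound 3 `OC[C@H]1C[C@@H](Cn2cnc3c(Cl)ncnc32)c2ccccc21` is the next to be read. It carries chloro in place of 4-methylphenyl on an aromatic carbon of the six-membered aromatic ring with 2 nitrogen, (chloro in place of 4-methylphenyl on an aromatic carbon).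

Among the measured compounds shown here, no step between measured compounds isolates a single change, so this expectation is loose. A moderate step towards a higher number, meaning weaker inhibition, is expected in this assay, only slightly beyond the scatter. The estimated step is a 2.1-fold higher number from compound 1 to compound 3 (0.33 log units; beyond the scatter). For compound 3 the estimate is 3 ug/mL, with an expected range of 0.9 ug/mL to 10 ug/mL.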

Compound 3, half-maximal inhibitory concentration: 24 ug/mL
The estimate for compound 3 lay 8.0-fold (0.90 log units) below the measured number, outside the stated range (above it).
By their numbers in this assay, from the lowest: compound 1; then compound 2; then compound 3.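

In this assay, among these compounds, chloro in place of 4-methylphenyl on an aromatic carbon gives a 17-fold higher number from compound 1 to compound 3 (1.23 log units; beyond the scatter) and provides the first comparison that isolates a single change. This position is therefore sensitive to its substituent, and of the two groups read here, 4-methylphenyl goes with the much stronger inhibition. Nothing available here accounts for the size of this step.

Among the compounds shown here, the comparison spans only two very different groups, so it cannot separate the contribution of the aromatic ring from that of its methyl group. Unsubstituted phenyl, a small alkyl group such as methyl, or an amine such as morpholine at this position would show whether the number changes gradually or depends specifically on 4-methylphenyl.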